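A Nitrophenyl Amide Variant of Compound 1

A few compounds are considered here, and "the series" means these few. Any claim that something is new, unique, unknown or untested is made for them only; others in the source may bear on it.

Of the compounds shown here, three built on one shared core have been tested in a functional assay on MKN-74 cells (Homo sapiens) for antiproliferative activity, with a stated time of 24 h; a higher number here means a weaker inhibitor, a lower number a stronger inhibitor. Compound 1 `NC(=O)c1c(NC(=O)c2ccccc2Cl)sc2c1CCN(C(=O)Nc1ccccc1Cl)C2` gives 16300 nM. Compound 2 `COc1ccccc1NC(=S)N1CCc2c(sc(NC(=O)c3ccccc3Cl)c2C(N)=O)C1` gives 35200 nM, and compound 3 `NC(=O)c1c(NC(=O)c2ccccc2Cl)sc2c1CCN(C(=S)Nc1cccnc1)C2` gives 38600 nM. Compound 1 stands with the lowest number of the three, and so is the strongest inhibitor among them: the steps of a 2.2-fold higher number from compound 1 to compound 2 (0.33 log units; beyond the scatter) and a 2.4-fold higher number from compound 1 to compound 3 (0.37 log units; beyond the scatter) both go to higher numbers, while the step of a 1.1-fold higher number from compound 2 to compound 3 (0.04 log units; within the scatter) lies within the scatter. All three of these steps alter only the group attached to the amine nitrogen in the ring.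

Compound 4 `NC(=O)c1c(NC(=O)c2cccc([N+](=O)[O-])c2)sc2c1CCN(C(=O)Nc1ccccc1Cl)C2` is not yet measured. It differs from compound 1 in another part of the molecule: 3-nitrophenyl in place of 2-chlorophenyl on a carbonyl carbon. Going by the values given here, none of the measured steps touches this amide end, so no step in this small set speaks directly to the change. With no such guidance, the plainest expectation is that compound 4 stays close to compound 1, with no step beyond the scatter. The step of a 1.2-fold higher number from compound 1 to compound 4 (0.09 log units; within the scatter) is therefore expected to be small. Compound 4 is expected to give about 20000 nM in this assay, within an estimated range of 6000 nM to 65000 nM.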

Compound 4, half-maximal inhibitory concentration: 22700 nM
Compound 4: the middle estimate sits 1.1-fold (0.05 log units) below what was measured; measured number inside the range.
By their numbers in this assay, from the lowest: compounds 1, 4, 2 and 3 (each within the scatter of the next, the first and the last beyond it).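

Going by these compounds alone, compound 4 gives the first reading at the amide end of the molecule, since the earlier steps all changed only the group on the amine nitrogen in the ring. In this assay, 3-nitrophenyl in place of 2-chlorophenyl on a carbonyl carbon gives a 1.4-fold higher number from compound 1 to compound 4 (0.14 log units; within the scatter) and so leaves compound 1 and compound 4 indistinguishable here, even though the two groups share only the six-membered carbon ring and differ in what that ring carries. Nothing available explains this result or shows how either group acts in these cells.

This single swap changes both the substituent and its numbered place on the ring, so the contribution of each stays unresolved, and a plain phenyl, a 2-nitrophenyl or a 3-chlorophenyl on the same carbonyl carbon would be needed to pull them apart. Also open, as far as these compounds go, is whether this end accepts very different groups, such as an aminophenyl, a carboxylic acid or a short alkyl chain, and whether 3-nitrophenyl behaves the same way alongside the other groups on the amine nitrogen.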